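Sulfoxide to sulfone on a triazole anticonvulsant series

The source may hold more compounds than are shown below. What is called first, only, known or untested is meant among the compounds shown, and "the series" means these compounds.

Compound 1 `Cn1c(-c2cccs2)nnc1[S+](C)[O-]` and compound 2 `Cn1c(-c2cccs2)nnc1S(C)(=O)=O` share one core; compound 3 `Cc1ccc(-c2nnc([S+](C)[O-])n2C)cc1` and compound 4 `Cc1ccc(-c2nnc(S(C)(=O)=O)n2C)cc1` share another, and the difference between the two cores is not broken down here. In a functional assay on the whole organism for antagonist activity, with Mus musculus as the target, in the maximal electroshock model (on this read-out higher numbers stand for an effect only at larger amounts of compound and lower numbers for an effect already at smaller amounts), compound 1 returns only a limit, > 200 mg/kg. Compound 2 likewise returns only a limit in this assay, > 200 mg/kg. Compound 3 too gives only a limit in this assay, > 200 mg/kg. The change from compound 1 to compound 2 is a group of 4 heavy atoms (1 carbon, 2 oxygen, 1 sulfur; no ring) in place of a group of 3 heavy atoms (1 carbon, 1 oxygen, 1 sulfur; no ring), on an aromatic carbon, and the step it made, a step that the two limits leave unreadable from compound 1 to compound 2, cannot be read because of the limit of > 200 mg/kg in this assay, at which 3 of the 3 values shown sit. The change from compound 3 to compound 4 is a group of 4 heavy atoms (1 carbon, 2 oxygen, 1 sulfur; no ring) in place of a group of 3 heavy atoms (1 carbon, 1 oxygen, 1 sulfur; no ring), on an aromatic carbon; the surroundings differ in the group borne by the ring atom two ring bonds from the changed position, so this is the same kind of change, not the same change. Compound 4 is not yet measured in this assay. For compound 4 the expected step that the limit leaves unreadable from compound 3 to compound 4 rests on compound 3 giving only a limit, > 200 mg/kg, in this assay. Compound 4 is therefore estimated at 300 mg/kg, with a range from 120 mg/kg to 1000 mg/kg, most likely again reported only as a limit.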

Compound 4, dose for half-maximal effect: > 200 mg/kg
Compound 4 ended at the assay's limit (the forecaster's own chance of this, stated with the estimate: 85%); the middle value is on the limit's open side.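

No step can be read from compound 3 to compound 4, any more than from compound 1 to compound 2, in this assay because all four compounds stop at the same limit: the limit of > 200 mg/kg in this assay, at which 4 of the 4 values shown sit.

The compounds shown leave open whether any of them has a half-maximal dose readable as a number, and so whether methylsulfonyl shifts that dose on either core.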